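The source may hold more compounds than are shown below. What is called first, only, known or untested is meant among the compounds shown, and "the series" means these compounds.

Working notes on the series, which shares one core: a thiophene sulfonamide linked through a two-carbon chain to a urea or thiourea bearing a disubstituted aniline.

Compound 1 is `O=C(NCCNS(=O)(=O)c1ccc(-c2ccccc2OCc2cccc(O)c2)s1)Nc1cc(Cl)cc(Cl)c1`. In a functional assay on RS4-11 cells (Homo sapiens) for inhibition, read by CCK-8 assay, with a stated time of 48 h (on this read-out higher numbers stand for weaker inhibition and lower numbers for stronger inhibition), compound 1 gives only a limit of the assay, > 50000 nM, so no number is known for it. Compound 1 therefore stands at the limit of > 50000 nM in this assay, at which 2 of the 3 values shown sit, and nothing shown separates it from the other compound at that limit. Compound 2 is `O=S(=O)(NCCNC(=S)Nc1cc(C(F)(F)F)cc(C(F)(F)F)c1)c1ccc(-c2ccccc2OCc2ccccc2)s1`. In this assay compound 2 also gives only a limit, > 50000 nM. Compound 3 is `COc1ccc(Oc2ccccc2-c2ccsc2S(=O)(=O)NCCNC(=S)Nc2cc(C(F)(F)F)cc(C(F)(F)F)c2)cc1OC`. In this assay, going by the values given here, compound 3 gives a measured value, 3300 nM, the one number in the set. Among the compounds with values here, no pair of measured compounds differs in a single place, so no measured step is available.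

Compound 4 is `O=C(NCCNS(=O)(=O)c1ccc(-c2ccccc2OCc2ccccc2)s1)Nc1cc(Cl)cc(Cl)c1`. It differs from compound 1 by hydrogen in place of hydroxy on an aromatic carbon. Since compound 1 is known only as a limit, the size of this step cannot be read from the shown values. The expectation is no step beyond the usual scatter, estimated as a step that the limit leaves unreadable from compound 1 to compound 4, with compound 4 most likely again reported as a limit. Compound 4 is expected at 60000 nM, within a range of 15000 nM to 250000 nM.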

Compound 4, half-maximal inhibitory concentration: > 20000 nM
Compound 4 ended at the assay's limit (the forecaster's own chance of this, stated with the estimate: 75%); the middle value is on the limit's open side.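

In this assay compound 1 gives > 50000 nM, a limit. Compound 4 gives > 20000 nM, also a limit. The two limits leave the step between these compounds unreadable. The compounds shown leave open whether hydrogen in place of hydroxy on an aromatic carbon changes inhibition at all in this assay.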